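Working notes: the step from compound 3 to compound 4

The source may report more compounds than this note shows. Statements on the series, on what has been measured and on what is new or still open speak of the compounds shown alone.

Values in a physicochemical assay for solubility, in phosphate buffer, at pH 7.4 (a lower number here means a less soluble compound, a higher number a more soluble compound), so far
- compound 1 `CNC(=O)CN1CCC(c2cc3c(-c4ccc(=O)n(C(C)C)c4)ccnc3[nH]2)CC1` gives 34000 nM as measured
- compound 2 `CC(C)n1nc(-c2ccnc3[nH]c(C4CCN(CC(=O)N(C)C)CC4)cc23)ccc1=O` gives 11000 nM as measured
- compound 3 `CC(C)n1cc(-c2ccnc3[nH]c(C4CCN(CC(=O)N(C)C)CC4)cc23)cnc1=O` gives 910000 nM as measured

Compound 3 stands highest of the three, with 910000 nM as the top number and both others lower beyond the scatter. Going by the values given here, compound 4 `COc1cc(=O)n(C)cc1-c1ccnc2[nH]c(C3CCN(CC(=O)N(C)C)CC3)cc12` differs from it by a group of 10 heavy atoms (7 carbon, 1 nitrogen, 2 oxygen; one six-membered aromatic ring with 1 hetero atom) in place of a group of 10 heavy atoms (7 carbon, 2 nitrogen, 1 oxygen; one six-membered aromatic ring with 2 hetero atoms), on an aromatic carbon as the single change. Among the compounds with values here, the one measured step at this place is an 83-fold higher number from compound 2 to compound 3 (1.92 log units; beyond the scatter) and it was large, so exchange of this group can move the number far. Within the data shown here, no measured compound carries the entering group. With compound 1 at 34000 nM and compound 2 at 11000 nM both well under compound 3, a large downward step is expected in this assay for this exchange. The expected step is a 15-fold lower number from compound 3 to compound 4 (1.18 log units; beyond the scatter) on this reasoning. For compound 4 the expected value is 60000 nM within an estimated range from 12000 nM to 300000 nM as a working figure.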

Compound 4, solubility: 670000 nM
Beside the measured number, compound 4's estimate is 11-fold (1.05 log units) below it; measured number above the stated range.
By their numbers in this assay, from the lowest: compound 2; then compound 1; then compounds 4 and 3 (each within the scatter of the next).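

In this assay, a second ring group on this aromatic carbon, opposite the ring nitrogen, gives a 1.4-fold lower number from compound 3 to compound 4 (0.13 log units; within the scatter), so the high number is not unique to the group in compound 3. The same exchange gives a 61-fold higher number from compound 2 to compound 4 (1.78 log units; beyond the scatter), and among compounds 2, 3 and 4 it is compound 2 that stands apart. Nothing at hand bears on the cause of this result.

Open, as far as these compounds go, is what a ring group carrying an amine or a carboxylic acid would give on this carbon. Also open, from the compounds shown here alone, is how a longer chain on the ring nitrogen would read in this assay.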